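Working notes: phenyl for methyl on the shared core

A few compounds are considered here, and "the series" means these few. Any claim that something is new, unique, unknown or untested is made for them only; others in the source may bear on it.

Compound 1 `CC(C)(C)NCC(O)COc1ncns1`: 91% in a functional assay on the whole organism (heart, strain mongrel) for inhibition, with Canis familiaris (Canis lupus familiaris) as the target, with a stated time of 20 min, at a dose of 4.58 mg/kg by the intravenous route; a lower number here means a weaker effect, a higher number a stronger effect of the compound at the dose given
Compound 2 `Cc1nsc(OCC(O)CNC(C)(C)C)n1`: 59.8%

Compound 2 stands lowest of the two numbers; the nearest is compound 1, higher by a step beyond the scatter. Compound 3 `CC(C)(C)NCC(O)COc1nc(-c2ccccc2)ns1` differs from compound 2 by phenyl in place of methyl on an aromatic carbon. Among the measured compounds shown here, the only measured step that bears on this is a number 31.2 percentage points lower from compound 1 to compound 2 (beyond the scatter), a large drop when a group was put on the same aromatic carbon. Whether a bulkier group lowers the read-out further is not shown by these two compounds, so the expectation is uncertain. A further lowering is expected, a number 14.8 percentage points lower from compound 2 to compound 3 (beyond the scatter). Compound 3 is estimated at 45%, between 15% and 80%.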

Compound 3, a percentage reported as inhibition, in the whole organism at one dose (the size of the read-out at that dose, not a potency): 23.8%
Compound 3: middle estimate off by 21.2 percentage points, on the high side, within the range that was stated.
By their numbers in this assay, from the lowest: compound 3; then compound 2; then compound 1.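

Phenyl on the aromatic carbon between two ring nitrogen atoms gives a number 36 percentage points lower from compound 2 to compound 3 (beyond the scatter) in this assay and, set against hydrogen, a number 67.2 percentage points lower from compound 1 to compound 3 (beyond the scatter) at the same place. Methyl was therefore not the end of the fall: hydrogen, methyl and phenyl at this position stand in falling order, and none of the three compounds goes against it. No measurement at hand explains this order.

Going by these compounds, whether an amine, a methoxy group or a carboxylic acid on this carbon would fit that order stays open. So does the effect of a chain such as ethyl or butyl there.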